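Amine methylation across two cores

The source may hold more compounds than are shown below. What is called first, only, known or untested is meant among the compounds shown, and "the series" means these compounds.

Compound 1 `CNCC(=O)Nc1cc(OC)ccc1C(=O)c1ccc2c(c1)C=CC(C)(C)O2` gives 800 nM in a functional assay on A549 cells (Homo sapiens) for antiproliferative activity, read by MTT assay, with a stated time of 48 h; a lower number here means a stronger inhibitor, a higher number a weaker inhibitor. Compound 2 `COc1ccc(C(=O)c2ccc3c(c2)C=CC(C)(C)O3)c(NC(=O)CN(C)C)c1` carries the change methyl in place of hydrogen on an amine nitrogen and in this assay compound 2 gives 1160 nM; the step between them is a 1.5-fold higher number from compound 1 to compound 2 (0.16 log units; within the scatter). Compound 3 `C=C(c1ccc2c(c1)C=CC(C)(C)O2)c1ccc(OC)cc1NC(=O)CN` is built on another core; the difference between the core of compound 1 and the core of compound 3 is not broken down here. In this assay compound 3 gives 60 nM, the lowest of the three measured numbers. Compound 4 `C=C(c1ccc2c(c1)C=CC(C)(C)O2)c1ccc(OC)cc1NC(=O)CNC` is not yet measured; it differs from compound 3 by methyl in place of hydrogen on an amine nitrogen. This is the same kind of change as from compound 1 to compound 2, though the amine nitrogen in compound 3 has one saturated chain carbon as its other neighbour, whereas in compound 1 it has two saturated chain carbons. Because the step of a 1.5-fold higher number from compound 1 to compound 2 (0.16 log units; within the scatter) stayed within the scatter, a similarly small step a 1.4-fold higher number from compound 3 to compound 4 (0.15 log units; within the scatter) is expected here. Compound 4 is therefore estimated at 85 nM, with a plausible range from 40 nM to 180 nM.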

Compound 4, half-maximal inhibitory concentration: 200 nM
Compound 4: middle estimate off by 2.4-fold (0.37 log units), on the low side; the whole stated range lies below it.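

In this assay, methyl in place of hydrogen on an amine nitrogen gives a 3.3-fold higher number from compound 3 to compound 4 (0.52 log units; beyond the scatter), so on the core of compound 3 the change weakens the compound beyond the scatter. Set beside the earlier step, the result does not separate the two cores for this change: the same change on two cores in this assay, a 1.5-fold higher number (0.16 log units; within the scatter) from compound 1 to compound 2 and a 3.3-fold higher number (0.52 log units; beyond the scatter) from compound 3 to compound 4, 2.3-fold (0.36 log units) apart, within the scatter of two such steps This agreement rests on only two steps, one within the scatter and one beyond it, and the amine of compound 1 already carries a methyl while that of compound 3 carries none, so no general rule for other cores follows.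

Still open, on these data alone, is whether a second methyl on the amine nitrogen of compound 4 weakens the compound further on this core. As far as these compounds go, the effect of an ethyl group, a longer chain or a pyrrolidine ring at that nitrogen is also open.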